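The source may report more compounds than this note shows. Statements on the series, on what has been measured and on what is new or still open speak of the compounds shown alone.

Measured in a functional assay on Jurkat cells (Homo sapiens) for cytotoxicity, read by MTT assay, with a stated time of 24 h; a higher number here means that more compound is needed for the effect, a lower number that less compound is needed:

- Compound 1 (`CCOC(=O)c1cc([Se]Cc2ccccc2)c2cc(OC)ccc2n1`): 20800 nM
- Compound 2 (`COc1ccc([Se]c2cc(-c3ccc(O)cc3)nc3ccc(OC)cc23)cc1`): 41500 nM
- Compound 3 (`CCOC(=O)c1cc([Se]c2ccccc2)c2cc(Cl)ccc2n1`): 53000 nM

Compound 1 sits at the low end of these numbers. Compound 2 lies within the usual scatter of it, while compound 3 has a higher number, beyond the scatter.

The next compound to be tested, compound 4 (`CCOC(=O)c1cc([Te]c2ccccc2)c2cc(OC)ccc2n1`), keeps the core of compound 1 and changes one group: a group of 7 heavy atoms (6 carbon, 1 tellurium; one six-membered aromatic ring of carbon only) in place of a group of 8 heavy atoms (7 carbon, 1 selenium; one six-membered aromatic ring of carbon only), on an aromatic carbon. A group holding tellurium replaces a group holding selenium, on an aromatic carbon opposite the ring nitrogen and meta to an ethoxycarbonyl group.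

Among the compounds with values here, none of the measured compounds holds tellurium, and no pair of them differs in just one place, so the data give no direct guide to this change. Within the data shown here, the only guide is the narrow spread of the numbers, from compound 1 at 20800 nM to compound 3 at 53000 nM, across compounds with differing structures. On that basis, no step beyond the scatter is expected in this assay, in either direction, and the range must stay wide. The expected step is a 1.0-fold lower number from compound 1 to compound 4 (0.02 log units; within the scatter). For compound 4 the estimated value is 20000 nM, with an expected range of 7000 nM to 55000 nM.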

Compound 4, half-maximal effective concentration: 77400 nM
Compound 4: middle estimate off by 3.9-fold (0.59 log units), on the low side; measured number outside the range, above it.
By their numbers in this assay, from the lowest: compounds 1, 2, 3 and 4 (each within the scatter of the next, the first and the last beyond it).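

In this assay, within the data shown here, the change at this position gives a 3.7-fold higher number from compound 1 to compound 4 (0.57 log units; beyond the scatter) and so, for the first time in this set, shows a single-place change that moves the number beyond the scatter, with more compound needed for the effect. The position on the aromatic carbon opposite the ring nitrogen is therefore not indifferent to what it carries, at least for this pair. The step belongs to the whole exchange, since the group of 7 heavy atoms (6 carbon, 1 tellurium) differs from the group of 8 heavy atoms (7 carbon, 1 selenium) in both its element and its size, and nothing measured here accounts for the step.

Still open, from the compounds shown here alone, is how a benzyl group held on tellurium, or a phenyl group held on selenium, would read on the core of compound 1, which would separate the element from the rest of the exchange. Also open, going by these compounds, is whether the step would stay the same with a carboxylic acid in place of the ethoxycarbonyl group.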